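Methyl removal on the pyrazolyl ring of compound 2

The compounds below may be only part of what the source reports. "The series", "measured", "known", "first", "only" and "open" are said of these compounds alone.

Three members of this series have been characterised in a physicochemical assay for lipophilicity; on this read-out lower numbers stand for lower lipophilicity and higher numbers for higher lipophilicity. Compound 1 `COCCNCCCS(=O)(=O)c1ccc2nc(NC(=O)NC(=O)c3ccccc3Cl)sc2c1` gives 1.3. Compound 2 `Cc1cc(C)n(-c2ccc(Cl)c(C(=O)NC(=O)Nc3nc4ccc(S(=O)(=O)CCCN5CCN(C)CC5)cc4s3)c2)n1` gives 2.5, and compound 3 `Cc1ccnn1-c1ccc(Cl)c(C(=O)NC(=O)Nc2nc3ccc(S(=O)(=O)C4CCN(C)CC4)cc3s2)c1` gives 2.6; compound 2 and compound 3 differ by less than the scatter of this assay, whereas compound 2 stands clearly above compound 1.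

Compound 4 `Cc1ccn(-c2ccc(Cl)c(C(=O)NC(=O)Nc3nc4ccc(S(=O)(=O)CCCN5CCN(C)CC5)cc4s3)c2)n1` is not yet measured. Relative to compound 2 it carries the change (hydrogen in place of methyl on an aromatic carbon), which reads, one bond further out, as 3,5-dimethyl-1H-pyrazol-1-yl to 3-methyl-1H-pyrazol-1-yl. For the measured compounds named here, no pair of measured compounds shows this change, so its size is not known from this series. A small drop is expected, with the step from compound 2 to compound 4 estimated at a number 0.40 log units lower from compound 2 to compound 4 (beyond the scatter), close to the scatter. Compound 4 is therefore expected to give about 2.1, within 1.6 to 2.6.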

Compound 4, distribution coefficient: 2.6
For compound 4 the middle estimate is 0.50 log units below the measured one; measured number inside the range.
By their numbers in this assay, from the lowest: compound 1; then compounds 2, 3 and 4 (each within the scatter of the next).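

In this assay this change can now be read directly, with a step of a number 0.10 log units higher from compound 2 to compound 4 (within the scatter) for hydrogen in place of methyl on this aromatic carbon. At this position, next to the ring atom that bears a large group, the 3,5-dimethyl-1H-pyrazol-1-yl and 3-methyl-1H-pyrazol-1-yl groups are not separated by this read-out. No measurement at hand accounts for this result. The compounds shown leave open how an ethyl or methoxy group on this carbon would read. Also open, going by these compounds, is whether hydrogen in place of the remaining methyl group would give a similar step.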